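A few compounds are considered here, and "the series" means these few. Any claim that something is new, unique, unknown or untested is made for them only; others in the source may bear on it.

In an ADME assay on J774.A1 cells (Mus musculus) for cytotoxicity, read by MTT assay, with a stated time of 72 h (a lower number here means that less compound is tolerated, a higher number that more compound is tolerated), compound 1 `COC(=O)C1=C(C)N(c2ccc(OC)cc2)C(C)=C(C(=O)OC)C1[C@@H]1O[C@H]2OC(C)(C)O[C@H]2[C@@H]1OCc1ccccc1` gives 14.1 ug/mL, compound 2 `COC(=O)C1=C(C)N(c2ccc(C)cc2)C(C)=C(C(=O)OC)C1[C@@H]1O[C@H]2OC(C)(C)O[C@H]2[C@@H]1OCc1ccccc1` gives 7.66 ug/mL and compound 3 `COC(=O)C1=C(C)N(c2ccc(C)cc2)C(C)=C(C(=O)OC)C1[C@@H]1O[C@H]2OC(C)(C)O[C@H]2[C@@H]1OC` gives 33.1 ug/mL, the highest of the three numbers. Compound 4 `COC(=O)C1=C(C)N(c2ccc(Cl)cc2)C(C)=C(C(=O)OC)C1[C@@H]1O[C@H]2OC(C)(C)O[C@H]2[C@@H]1OC` has not yet been measured. It differs from compound 3 by chloro in place of methyl on an aromatic carbon, para to a large group: chloro in place of methyl on an aromatic carbon. The closest measured precedent is a 1.8-fold lower number from compound 1 to compound 2 (0.26 log units; within the scatter), another exchange on that aromatic carbon, and it stayed within the scatter. The larger 4.3-fold higher number from compound 2 to compound 3 (0.64 log units; beyond the scatter) lies elsewhere in the structure and bears less on this change. No step beyond the scatter is therefore expected in this assay. The expected step is a 1.1-fold lower number from compound 3 to compound 4 (0.04 log units; within the scatter). For compound 4, the estimated value is 30 ug/mL, with an expected range from 14 ug/mL to 62 ug/mL.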

Compound 4, half-maximal cytotoxic concentration: 82.4 ug/mL
Compound 4: the middle estimate sits 2.7-fold (0.44 log units) below what was measured; the measured number lies above the stated range.
By their numbers in this assay, from the lowest: compounds 2 and 1 (each within the scatter of the next); then compound 3; then compound 4.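

In this assay the exchange of methyl for chloro on this aromatic carbon, para to a large group, gives a 2.5-fold higher number from compound 3 to compound 4 (0.40 log units; beyond the scatter) and so shows that this position can move the number beyond the scatter. The earlier exchange on the same carbon, a 1.8-fold lower number from compound 1 to compound 2 (0.26 log units; within the scatter), stayed within it, so the outcome here depends on the incoming group, the rest of the structure or both. Nothing available explains the step. From the compounds shown here alone, it remains open whether chloro would give a similar step with the phenyl group of compound 2 present. Going by these compounds, how a fluoro or a nitrile would read at this place also remains open.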